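The source may report more compounds than this note shows. Statements on the series, on what has been measured and on what is new or still open speak of the compounds shown alone.

Working notes on the chalcone series. Compound 1 `COc1cc(OC)c(C(=O)/C=C/c2cccc([N+](=O)[O-])c2)c(O)c1CC=C(C)C` in an ADME assay on MCF7-DOX cells (Homo sapiens) for cytotoxicity, read by MTT assay, with a stated time of 48 h (on this read-out higher numbers stand for weaker inhibition and lower numbers for stronger inhibition), gives 57000 nM. Going by the values given here, the only other measured member, compound 2 `COc1cc(OC)c(C(=O)/C=C/c2cccc(N3CCNCC3)c2)c(O)c1C`, in this assay gives 98700 nM; the two numbers lie within the scatter of each other, so compound 1 cannot be set apart from compound 2 on what is known. Compound 3 `COc1cc(OC)c(C(=O)/C=C/c2cccc(C(F)(F)F)c2)c(O)c1CC=C(C)C` remains to be measured. It differs from compound 1 as follows: trifluoromethyl in place of nitro on an aromatic carbon. Among the compounds with values here, no measured step bears on this change, so the expectation is a step from compound 1 to compound 3 of a 1.0-fold lower number from compound 1 to compound 3 (0.02 log units; within the scatter), none beyond the scatter. Compound 3 is therefore expected to give about 55000 nM, with a range from 20000 nM to 150000 nM.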

Compound 3, half-maximal inhibitory concentration: 66600 nM
Beside the measured number, compound 3's estimate is 1.2-fold (0.08 log units) below it; the measured number falls inside the stated range.
By their numbers in this assay, from the lowest: compounds 1, 3 and 2 (each within the scatter of the next).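

In this assay, going by these compounds alone, the 3-nitrophenyl to 3-(trifluoromethyl)phenyl change gives a 1.2-fold higher number from compound 1 to compound 3 (0.07 log units; within the scatter) and is the only measured step at this position. A group with no hydrogen-bond acceptors thus stands in for one that has them, with no step beyond the scatter. No available evidence bears on why these two groups read alike. On these data alone, whether an amine, a carboxylic acid or a methoxy group on this aromatic carbon would stay within the scatter of compound 1 remains open.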